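Carbonyl substituent at the aryl position: carbamoyl to carboxy

The compounds below may be only part of what the source reports. "The series", "measured", "known", "first", "only" and "open" are said of these compounds alone.

Within the data shown here, compound 3 `Cn1c(-c2ccc(C(N)=O)cc2Cl)nnc1C1(c2ccc(Cl)cc2)CCC1` has the lowest number of the three measured members in a functional assay on the whole organism (strain ICR) for inhibition, with Mus musculus as the target, read by scintillation counting, with a stated time of 16 h, at a dose of 10 mg/kg by the oral route (a higher number here means more inhibition at the dose given (going by the name of the read-out), a lower number less inhibition), where compound 3 gives 12%. Compound 1 `CC(=O)Nc1ccc(-c2nnc(C3(c4ccc(Cl)cc4)CCC3)n2C)c(Cl)c1` gives 27% and compound 2 `Cn1c(-c2ccc(N)cc2Cl)nnc1C1(c2ccc(Cl)cc2)CCC1` gives 38%, so both steps into compound 3 run downward: a number 15 percentage points lower from compound 1 to compound 3 (beyond the scatter) and a number 26 percentage points lower from compound 2 to compound 3 (beyond the scatter). Between the other two the step is a number 11 percentage points higher from compound 1 to compound 2 (beyond the scatter).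

Compound 4 `Cn1c(-c2ccc(C(=O)O)cc2Cl)nnc1C1(c2ccc(Cl)cc2)CCC1` differs from compound 3 only at the carbonyl carbon: hydroxy in place of amino on a carbonyl carbon. Among the measured compounds shown here, no measured pair shows this exact exchange, so the only steps that bear on it are those that replace the group on the aromatic carbon, which moved the read-out by modest amounts and, where a carbonyl entered, downward. Compound 3 already sits at the bottom of the measured range, and a change that keeps the carbonyl while swapping one single-atom donor for another is expected to move the number little in this assay; the expected step is a number 2 percentage points lower from compound 3 to compound 4 (within the scatter), not beyond the scatter.

Compound 4 is therefore estimated at 10% in this assay, with a range from 0% to 28%.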

Compound 4, a percentage reported as inhibition, in the whole organism at one dose (the size of the read-out at that dose, not a potency): 38%
Beside the measured number, compound 4's estimate is 28 percentage points below it; measured number outside the range, above it.
By their numbers in this assay, from the lowest: compound 3; then compound 1; then compounds 2 and 4 (each within the scatter of the next).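

At this carbonyl carbon, the exchange of one atom is not silent: in this assay, hydroxy in place of amino gives a number 26 percentage points higher from compound 3 to compound 4 (beyond the scatter) and so separates two groups that both keep the carbonyl. A carbonyl on the aromatic carbon therefore does not by itself go with a low number, as the step into compound 3 had suggested; compound 4 goes against that reading, with carboxy in place of amino giving no change at the digits printed from compound 2 to compound 4 (within the scatter) and carboxy in place of acetamido giving a number 11 percentage points higher from compound 1 to compound 4 (beyond the scatter) in the same read-out. Nothing measured in the series accounts for the gap between carbamoyl and carboxy.

Still open, from the compounds shown here alone, is whether a methyl ester or a sulfonamide on this aromatic carbon would read with carboxy or with carbamoyl, which would show how narrow the low number of carbamoyl is. Also open, going by these compounds, is whether the match between compound 2 and compound 4 holds at other doses and times, since each number here is the size of the read-out at one oral dose and not a potency.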